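This account rests on a few compounds, and the source may have more. Where it says the series, first, only, none or still open, it means among the compounds named here.

Measured so far in a physicochemical assay for metabolic stability, read by HPLC; a higher number here means that the compound lasts longer, a lower number that the compound disappears faster:
- compound 1 `Cc1cn([C@H]2C[C@H](N=[N+]=[N-])[C@@H](COP(=O)(O)Oc3ccc(C#N)cc3)O2)c(=O)[nH]c1=O`: 7.08 h
- compound 2 `Cc1cn([C@H]2C[C@H](N=[N+]=[N-])[C@@H](COP(=O)(O)Oc3cccnc3)O2)c(=O)[nH]c1=O`: 3.88 h
- compound 3 `Cc1cn([C@H]2C[C@H](N=[N+]=[N-])[C@@H](COP(=O)(O)Oc3ccccc3)O2)c(=O)[nH]c1=O`: 9.47 h

Two steps fix where compound 3 stands in this assay. The first is a 1.3-fold higher number from compound 1 to compound 3 (0.13 log units; within the scatter), which does not separate the two compounds. The second is a 2.4-fold higher number from compound 2 to compound 3 (0.39 log units; beyond the scatter), the only one of the measured gaps around compound 3 that clears the scatter.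

The next structure is compound 4 `Cc1cn([C@H]2C[C@H](N=[N+]=[N-])[C@@H](COP(=O)(O)Oc3cncc(Cl)c3)O2)c(=O)[nH]c1=O`, which differs from compound 3 in one place: 5-chloropyridin-3-yl in place of phenyl on an oxygen. In words, this is 5-chloropyridin-3-yl in place of phenyl on an oxygen.

Among the compounds with values here, two measured steps bear on this change. The exchange of the phenyl ring for a pyridine ring runs against the direction of a 2.4-fold higher number from compound 2 to compound 3 (0.39 log units; beyond the scatter), so that step is the closest guide and points to a lower number. The other guide is a 1.3-fold higher number from compound 1 to compound 3 (0.13 log units; within the scatter), which shows that removing a cyano group left the number within the scatter. Within the data shown here, no measured compound carries chlorine, so the share of that atom remains open.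

A modest fall is therefore expected, of about the size of the pyridine step. The expected step is a 3.0-fold lower number from compound 3 to compound 4 (0.47 log units; beyond the scatter). Compound 4 is estimated at 3.2 h, with an expected range of 1.6 h to 6.5 h.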

Compound 4, half-life: 7.27 h
For compound 4 the middle estimate is 2.3-fold (0.36 log units) below the measured one; measured number above the stated range.
By their numbers in this assay, from the lowest: compounds 2, 1, 4 and 3 (each within the scatter of the next, the first and the last beyond it).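

In this assay, 5-chloropyridin-3-yl on the oxygen bound to phosphorus is not separated from phenyl (a 1.3-fold lower number from compound 3 to compound 4 (0.11 log units; within the scatter)), whereas pyridin-3-yl does stand apart from phenyl (a 2.4-fold higher number from compound 2 to compound 3 (0.39 log units; beyond the scatter)); a ring with a hetero atom at this place therefore need not part from phenyl once it also carries chloro. The chloro step on its own stays within the scatter (a 1.9-fold higher number from compound 2 to compound 4 (0.27 log units; within the scatter)), and 5-chloropyridin-3-yl cannot be told apart from 4-cyanophenyl either (a 1.0-fold higher number from compound 1 to compound 4 (0.01 log units; within the scatter)), so compound 1, compound 3 and compound 4 read as one group, with compound 2 set apart from compound 3 alone. No measurement among the data accounts for these readings.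

The compounds shown leave open whether chloro would read the same on a phenyl ring, since here it appears only on the pyridine ring and at one place. They also leave open how bromo, methoxy, an amine or a carboxylic acid on the ring would read in this assay, and whether any of these would part clearly from phenyl.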